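Estimating Paw-Edema Inhibition for a Fluorophenyl Analogue

The compounds below may be only part of what the source reports. "The series", "measured", "known", "first", "only" and "open" are said of these compounds alone.

Compound 1 `O=c1oc2ccccc2cc1C1=NN(c2ccccc2)[C@@H](c2ccc(Cl)cc2Cl)C1` gives 67.5%
Compound 2 `Cc1ccc([C@H]2CC(c3cc4ccccc4oc3=O)=NN2c2ccccc2)cc1` gives 38%
Compound 3 `COc1cccc([C@H]2CC(c3cc4ccccc4oc3=O)=NN2c2ccccc2)c1` gives 61.5%

Three compounds sharing one core and differing only in the aryl group on a saturated ring carbon have been tested in a functional assay on the whole organism (strain albino) for inhibition, with Rattus norvegicus as the target, read by paw edema, with stated times of 1 h and 4 h, at a dose of 200 mg/kg by the oral route; a lower number here means less inhibition, a higher number more inhibition at the dose given (going by the name of the read-out). Compound 3 stands second highest of the three: the step of a number 6 percentage points lower from compound 1 to compound 3 (within the scatter) is within the scatter, whereas a number 23.5 percentage points higher from compound 2 to compound 3 (beyond the scatter) is beyond it. Compound 4 `O=c1oc2ccccc2cc1C1=NN(c2ccccc2)[C@@H](c2ccc(F)cc2)C1` carries 4-fluorophenyl in place of 3-methoxyphenyl on a saturated ring carbon. For the measured compounds named here, the steps that bear on this are a number 23.5 percentage points higher from compound 2 to compound 3 (beyond the scatter) and a number 29.5 percentage points lower from compound 1 to compound 2 (beyond the scatter), each modest; the 4-methylphenyl group of compound 2 lowered the read-out, while the chlorine-bearing group of compound 1 did not. A small drop is expected for compound 4, a number 11.5 percentage points lower from compound 3 to compound 4 (beyond the scatter). Compound 4 is therefore estimated at 50%, within 35% to 65%.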

Compound 4, a percentage reported as inhibition, in the whole organism at one dose (the size of the read-out at that dose, not a potency): 66.7%
Beside the measured number, compound 4's estimate is 16.7 percentage points below it, outside the stated range (above it).
By their numbers in this assay, from the lowest: compound 2; then compounds 3, 4 and 1 (each within the scatter of the next).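

With a number 5.2 percentage points higher from compound 3 to compound 4 (within the scatter) and a number 0.8 percentage points lower from compound 1 to compound 4 (within the scatter) in this assay the 4-fluorophenyl group reads level with the 3-methoxyphenyl and 2,4-dichlorophenyl groups, so quite different rings on this saturated carbon can give the same reading. Fluoro in place of methyl on the same ring gives a number 28.7 percentage points higher from compound 2 to compound 4 (beyond the scatter) and shows that compound 2 is the one compound that stands apart. Nothing measured here explains why.

Still open, as far as these compounds go, is whether other groups on this ring, such as an amine or a carboxylic acid, would also hold the reading or lower it as the methyl group did.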